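Dithiocarbamate piperazines: swapping the aryl group on compound 1

A few compounds are considered here, and "the series" means these few. Any claim that something is new, unique, unknown or untested is made for them only; others in the source may bear on it.

Measured compounds:
Compound 1, `Nc1nc(N)c2cc(CSC(=S)N3CCN(c4ccc(O)cc4)CC3)ccc2n1`: 5090 nM
Compound 2, `COc1ccc(N2CCN(C(=S)SCc3ccc4nc(N)nc(N)c4c3)CC2)cc1`: 1580 nM
Compound 3, `Cc1ccc(N2CCN(C(=S)SCc3ccc4nc(N)nc(N)c4c3)CC2)c(C)c1`: 3120 nM

In a functional assay on MCF7 cells (Homo sapiens) for antiproliferative activity, read by MTT assay, with a stated time of 72 h (a lower number here means a stronger inhibitor, a higher number a weaker inhibitor), compound 1 gives 5090 nM, the highest of the three numbers. Its nearest neighbour is compound 3, which stands a 1.6-fold lower number from compound 1 to compound 3 (0.21 log units; within the scatter), a gap that sits within the scatter; compound 2 is furthest, with a 3.2-fold lower number from compound 1 to compound 2 (0.51 log units; beyond the scatter).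

Compound 4, `Nc1nc(N)c2cc(CSC(=S)N3CCN(c4ccccc4F)CC3)ccc2n1`, has not yet been measured. Its change from compound 1 is 2-fluorophenyl in place of 4-hydroxyphenyl on an amine nitrogen in a ring. Going by the values given here, two measured steps bear on it, both of which remove the hydroxyl from the aryl group on the ring nitrogen: a 3.2-fold lower number from compound 1 to compound 2 (0.51 log units; beyond the scatter) and a 1.6-fold lower number from compound 1 to compound 3 (0.21 log units; within the scatter). Both move the number down, one beyond the scatter and one within it. Compound 4 is therefore expected to give a lower number than compound 1, by an estimated 2.0-fold lower number from compound 1 to compound 4 (0.29 log units; within the scatter), a step between those two. In this assay the value of compound 4 is estimated at 2600 nM, with a range from 1200 nM to 5600 nM.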

Compound 4, half-maximal inhibitory concentration: 4840 nM
Beside the measured number, compound 4's estimate is 1.9-fold (0.27 log units) below it; low and high end bracket the measured number.
By their numbers in this assay, from the lowest: compounds 2, 3, 4 and 1 (each within the scatter of the next, the first and the last beyond it).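

Putting 2-fluorophenyl in place of the 4-hydroxyphenyl of compound 1 removes the hydroxyl, yet in this assay the two compounds cannot be told apart (a 1.1-fold lower number from compound 1 to compound 4 (0.02 log units; within the scatter)), so at this position losing the hydroxyl does not by itself lower the number. Compound 4 also lies within the scatter of compound 3 (a 1.6-fold higher number from compound 3 to compound 4 (0.19 log units; within the scatter)) but not of compound 2 (a 3.1-fold higher number from compound 2 to compound 4 (0.49 log units; beyond the scatter)), which leaves compound 2, with its 4-methoxyphenyl, clearly apart from compound 1 and compound 4, though not from compound 3. Nothing measured here accounts for this difference among the aryl groups.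

The compounds shown leave open whether the separation of compound 2 is tied to its methoxy group. An ethoxy group or an amine on the aryl ring could test that.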